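Methyl to methoxy on the sulfonamide aryl group, ortho case

This account rests on a few compounds, and the source may have more. Where it says the series, first, only, none or still open, it means among the compounds named here.

Of the compounds shown here, three sharing one core have been measured, and a fourth awaits a number. Compound 1 `Cc1ccc(NS(=O)(=O)c2ccc(N3CCNC3=O)cc2)cc1` gives 260 nM in a functional assay on M21 cells (Homo sapiens) for antiproliferative activity, read by sulforhodamine B assay, with a stated time of 48 h; a lower number here means a stronger inhibitor, a higher number a weaker inhibitor. Compound 2 `COc1ccc(NS(=O)(=O)c2ccc(N3CCNC3=O)cc2)cc1` gives 580 nM in this assay; it differs from compound 1 by methoxy in place of methyl on an aromatic carbon, and this change produced a 2.2-fold higher number from compound 1 to compound 2 (0.35 log units; beyond the scatter). Compound 3 `Cc1ccccc1NS(=O)(=O)c1ccc(N2CCNC2=O)cc1` gives 150 nM in this assay; it differs from compound 1 in that the two have the same atoms joined differently, as 2-methylphenyl in place of 4-methylphenyl on a sulfonamide nitrogen, and the step of a 1.7-fold lower number from compound 1 to compound 3 (0.24 log units; within the scatter). Between compound 2 and compound 3 the step is a 3.9-fold lower number from compound 2 to compound 3 (0.59 log units; beyond the scatter).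

Compound 4 `COc1ccccc1NS(=O)(=O)c1ccc(N2CCNC2=O)cc1` has not yet been measured in this assay. It differs from compound 3 by methoxy in place of methyl on an aromatic carbon. This is the same kind of change as that from compound 1 to compound 2, but not the same: there the methoxy entered para to a large group, whereas here it enters ortho to a large group. Because the earlier change gave a 2.2-fold higher number from compound 1 to compound 2 (0.35 log units; beyond the scatter), the step from compound 3 to compound 4 is expected to be of about that size, a 2.2-fold higher number from compound 3 to compound 4 (0.34 log units; beyond the scatter), although the different placement leaves this uncertain. Compound 4 is therefore estimated at 330 nM in this assay, with a likely range from 150 nM to 750 nM.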

Compound 4, half-maximal inhibitory concentration: 300 nM
For compound 4 the middle estimate is 1.1-fold (0.04 log units) above the measured one, and the stated range covers the measured number.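

In this assay, methoxy in place of methyl gave a 2.0-fold higher number from compound 3 to compound 4 (0.30 log units; within the scatter), a step that stands close to the earlier one: the same change on two cores in this assay, a 2.2-fold higher number (0.35 log units; beyond the scatter) from compound 1 to compound 2 and a 2.0-fold higher number (0.30 log units; within the scatter) from compound 3 to compound 4, 1.1-fold (0.05 log units) apart, within the scatter of two such steps. The swap thus carried over at about the same size between these two cores, although the new step lies within the scatter and the earlier one beyond it. Two pairs do not make a rule for other cores, and the remaining steps, a 1.9-fold lower number from compound 2 to compound 4 (0.29 log units; within the scatter) and a 1.2-fold higher number from compound 1 to compound 4 (0.06 log units; within the scatter), both lie within the scatter, so neither separates compound 4 from compound 2 or compound 1.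

The compounds shown leave open whether a longer chain such as ethoxy, an amine or a carboxylic acid in the same place on the 2-methylphenyl group would follow the methoxy result. They also leave open whether the swap would keep its size on a core altered at the other end of the sulfonamide.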